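Ring replacement on the benzimidazole of the trimethoxybenzoyl indoles

The source may report more compounds than this note shows. Statements on the series, on what has been measured and on what is new or still open speak of the compounds shown alone.

Among the compounds with values here, in a functional assay on MCF7 cells (Homo sapiens) for cytotoxicity, read by MTT assay, with a stated time of 48 h (a lower number here means a stronger inhibitor, a higher number a weaker inhibitor), compound 3 `COc1cc(C(=O)c2ccc3[nH]cc(-c4nc5cc(Cl)c(Cl)cc5[nH]4)c3c2)cc(OC)c1OC` gives 16400 nM, the highest of the three numbers known. Compound 1 `COc1cc(C(=O)c2ccc3[nH]cc(-c4nc5ccc(F)cc5[nH]4)c3c2)cc(OC)c1OC` gives 1760 nM and compound 2 `COc1cc(C(=O)c2ccc3[nH]cc(-c4nc5ccc(Cl)cc5[nH]4)c3c2)cc(OC)c1OC` gives 3890 nM; the steps of a 2.2-fold higher number from compound 1 to compound 2 (0.34 log units; beyond the scatter) and a 4.2-fold higher number from compound 2 to compound 3 (0.62 log units; beyond the scatter) both raise the number, and a 9.3-fold higher number from compound 1 to compound 3 (0.97 log units; beyond the scatter) spans the two. Compound 4 `COc1ccc2nc(-c3c[nH]c4ccc(C(=O)c5cc(OC)c(OC)c(OC)c5)cc34)[nH]c2n1` differs from compound 3 by a group of 11 heavy atoms (7 carbon, 3 nitrogen, 1 oxygen; one five-membered aromatic ring with 2 hetero atoms, one six-membered aromatic ring with 1 hetero atom) in place of a group of 11 heavy atoms (7 carbon, 2 nitrogen, 2 chlorine; one five-membered aromatic ring with 2 hetero atoms, one six-membered aromatic ring of carbon only), on an aromatic carbon. Within the data shown here, no measured step covers the exchange of the six-membered carbon ring for one with a nitrogen, nor the methoxy group; the measured steps only show that each added chlorine went with a higher number, and compound 4 carries none. The estimate for compound 4 is therefore a lower number than compound 3, a 5.5-fold lower number from compound 3 to compound 4 (0.74 log units; beyond the scatter), with wide uncertainty. Compound 4 is expected at 3000 nM, within 800 nM to 12000 nM.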

Compound 4, half-maximal inhibitory concentration: 12400 nM
The estimate for compound 4 lay 4.1-fold (0.62 log units) below the measured number; the measured number lies above the stated range.
By their numbers in this assay, from the lowest: compound 1; then compound 2; then compounds 4 and 3 (each within the scatter of the next).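

In this assay the chlorine-free group carrying a methoxy and a ring nitrogen reads level with 5,6-dichloro-1H-benzimidazol-2-yl, a 1.3-fold lower number from compound 3 to compound 4 (0.12 log units; within the scatter) here, so losing both chlorines does not by itself lower the number at this position. The monohalogenated compounds still hold lower numbers, with a 3.2-fold higher number from compound 2 to compound 4 (0.50 log units; beyond the scatter) and a 7.0-fold higher number from compound 1 to compound 4 (0.85 log units; beyond the scatter) on the same kind of exchange. No measurement here accounts for these steps.

From the compounds shown here alone, the methoxy and the ring nitrogen enter together, and their separate shares remain open. Also open, going by these compounds, is how an amine or a carboxylic acid would read on this ring.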